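The compounds below may be only part of what the source reports. "The series", "measured", "known", "first", "only" and "open" are said of these compounds alone.

Compound 1 `CCN1CCN(c2cc(C)c3cc(NC(=O)c4ccc[nH]4)ccc3n2)CC1` — 14700 nM
Compound 2 `CNc1cc(C)c2cc(NC(=O)c3ccc(Cl)c(Cl)c3)ccc2n1` — 2520 nM
Compound 3 `CCN1CCN(c2cc(C)c3cc(NC(=O)c4cccc(Cl)c4)ccc3n2)CC1` — 3820 nM

All three were tested in a functional assay on MCF7 cells (Homo sapiens) for antiproliferative activity, read by MTT assay, with a stated time of 72 h; on this read-out higher numbers stand for weaker inhibition and lower numbers for stronger inhibition. Compound 2 gives the lowest of the three numbers. Its nearest neighbour is compound 3, whose number lies higher only within the usual scatter of repeated measurements, so the two cannot be told apart. Compound 1 is furthest away, and that gap is beyond the scatter. Going by the values given here, compound 2 and compound 3 differ in two places at once, so their values show only that the pair sits close together.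

Among the compounds with values here, the single step measured between compounds that differ in one place is a 3.8-fold lower number from compound 1 to compound 3 (0.59 log units; beyond the scatter), a modest step. It concerns the group on the carbonyl carbon, not the amine on the shared core.

Compound 4 `Cc1cc(N2CCN(C)CC2)nc2ccc(NC(=O)c3ccc(Cl)c(Cl)c3)cc12` has not yet been measured in this assay. Compared with compound 2 the change is 4-methylpiperazin-1-yl in place of methylamino on an aromatic carbon. Within the data shown here, no measured step touches this kind of change: compound 1 and compound 3 carry a different amine at that place, but they also differ from compound 2 in the group on the carbonyl carbon, so they give no clean comparison. With nothing pointing either way, a step within the scatter is expected. Compound 4 is therefore expected to give about 2500 nM, with a range from 900 nM to 7000 nM. This estimate means an expected step of a 1.0-fold lower number from compound 2 to compound 4 (0.00 log units; within the scatter).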

Compound 4, half-maximal inhibitory concentration: 3000 nM
Beside the measured number, compound 4's estimate is 1.2-fold (0.08 log units) below it, and the stated range covers the measured number.
By their numbers in this assay, from the lowest: compounds 2, 4 and 3 (each within the scatter of the next); then compound 1.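

In this assay, the step is a 1.2-fold higher number from compound 2 to compound 4 (0.08 log units; within the scatter), so replacing methylamino with 4-methylpiperazin-1-yl on this aromatic carbon, next to the ring nitrogen, gives no difference that can be told from repeat scatter. Going by these compounds alone, this is the first clean reading at this place, since the group on the carbonyl carbon stays the same here, whereas compound 1 and compound 3 also differ from compound 2 in that group. The swap is a large one on paper, with a group of 2 heavy atoms and 1 hydrogen-bond donor giving way to one of 7 heavy atoms, a non-aromatic ring and 0 hydrogen-bond donors, yet this one pair shows that the read-out can stay put across it, and no separate measurement bears on what lies behind that.

From the compounds shown here alone, whether the same holds with another group on the carbonyl carbon, such as 1H-pyrrol-2-yl or 3-chlorophenyl, remains open. Also open, going by these compounds, is whether a different group at this place, such as morpholin-4-yl, a plain amino group or a longer chain like 2-hydroxyethylamino, would stay as close to compound 2.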